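Swapping piperidin-4-yl for 2,2-diethoxyethyl on compound 1

The source may hold more compounds than are shown below. What is called first, only, known or untested is meant among the compounds shown, and "the series" means these compounds.

Measured in a functional assay on MCF7 cells (Homo sapiens) for inhibition, read by MTT assay, with a stated time of 72 h; on this read-out lower numbers stand for stronger inhibition and higher numbers for weaker inhibition:
- compound 1 `CC(C)=CCC[C@H](C)c1ccc(C)c(CNCC2CCNCC2)c1O`: > 20000 nM (a limit, not a number)
- compound 2 `CC(C)=CCC[C@H](C)c1ccc(C)c2c1OCN(CCCCCO)C2`: 6900 nM
- compound 3 `CCOC(CCN1COc2c([C@@H](C)CCC=C(C)C)ccc(C)c2C1)OCC`: 13200 nM

Compound 1 stands at the limit of > 20000 nM in this assay, at which 1 of the 3 values shown sits, so it has a limit and no number. Compound 4 `CCOC(CCNCc1c(C)ccc([C@@H](C)CCC=C(C)C)c1O)OCC` keeps the core of compound 1 and changes one side chain: 2,2-diethoxyethyl in place of piperidin-4-yl on a saturated chain carbon bound to an amine nitrogen. Put another way, (piperidin-4-yl)methyl gives way to 3,3-diethoxypropyl.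

Among the compounds with values here, no measured step joins these two compounds directly. The nearest evidence is a 1.9-fold higher number from compound 2 to compound 3 (0.28 log units; within the scatter), a step within the scatter, so exchanging that chain end showed no real difference in this assay. Compound 4 shares its 3,3-diethoxypropyl chain with compound 3, which gives 13200 nM on a different core. On that basis, the expected change is modest and toward lower numbers, estimated as an at least 1.3-fold lower number from compound 1 to compound 4 (0.12 log units; that floor lies within the scatter). Another limit would be no surprise. The estimated value for compound 4 is 15000 nM, with an expected range of 7000 nM to 30000 nM.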

Compound 4, half-maximal inhibitory concentration: 10300 nM
Compound 4: middle estimate off by 1.5-fold (0.16 log units), on the high side, within the range that was stated.
By their numbers in this assay, from the lowest: compounds 2, 4 and 3 (each within the scatter of the next). At a limit, above all of these: compound 1.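

In this assay, putting 2,2-diethoxyethyl in place of piperidin-4-yl on a saturated chain carbon bound to an amine nitrogen gives an at least 1.9-fold lower number from compound 1 to compound 4 (0.28 log units; that floor lies within the scatter). The true size of this step cannot be read, because compound 1 has only a limit and not a number: the limit of > 20000 nM in this assay, at which 1 of the 4 values shown sits.

Within the data shown here, what is new is that the 3,3-diethoxypropyl chain now has a measured value on the core of compound 1, where compound 4 gives 10300 nM, whereas the earlier compounds showed that chain only on the core of compound 3.

Still open, as far as these compounds go, is which part of the change matters, the loss of the piperidine ring or the arrival of the two ethoxy groups. A plain butyl chain or a chain ending in a carboxylic acid at this place on the core of compound 1 would help separate the two.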